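A few compounds are considered here, and "the series" means these few. Any claim that something is new, unique, unknown or untested is made for them only; others in the source may bear on it.

Series notes. Compound 1 `N#Cc1cc(-c2nc(C(c3ccc(F)cc3)c3ccc(F)cc3)sc2CC(=O)O)ccc1F` carries 3-cyano-4-fluorophenyl on an aromatic carbon of the shared core; in an in vitro functional assay on HEK285-7 cells for antagonist activity at prostaglandin D2 receptor 2 (Homo sapiens), read by BRET and beta-arrestin recruitment (a lower number here means a smaller maximal response, a higher number a larger maximal response), compound 1 reaches 80%. Compound 2 `O=C(O)Cc1sc(C(c2ccc(F)cc2)c2ccc(F)cc2)nc1-c1ccccc1` has plain phenyl in that position, and compound 2 reaches 80%, so that no change at the digits printed from compound 1 to compound 2 (within the scatter). Compound 3 `NS(=O)(=O)c1cccc(-c2nc(C(c3ccc(F)cc3)c3ccc(F)cc3)sc2CC(=O)O)c1` bears 3-sulfamoylphenyl there, and compound 3 reaches 55%, the lowest of the three numbers, the other two lying higher beyond the scatter: a number 25 percentage points lower from compound 1 to compound 3 (beyond the scatter) and a number 25 percentage points lower from compound 2 to compound 3 (beyond the scatter).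

Compound 4 `N#Cc1ccc(-c2nc(C(c3ccc(F)cc3)c3ccc(F)cc3)sc2CC(=O)O)cc1` is the next candidate and differs from compound 3 as follows: 4-cyanophenyl in place of 3-sulfamoylphenyl on an aromatic carbon The two measured steps that bear on this change both run toward compound 3 and both lowered the maximal response by about the same modest amount, namely a number 25 percentage points lower from compound 1 to compound 3 (beyond the scatter) and a number 25 percentage points lower from compound 2 to compound 3 (beyond the scatter). In compound 4 the sulfamoyl group is gone and a nitrile is present instead, as in compound 1. The step in this assay is therefore expected to run the other way, with a rise of roughly the size seen in those two steps, and the expected step is a number 23 percentage points higher from compound 3 to compound 4 (beyond the scatter). Compound 4 is estimated at 78%, with a range from 65% to 90%. This rests on compound 1, which also carries a nitrile and gave 80%.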

Compound 4, largest response reached (reported as efficacy), in percent of the reference or control that the assay uses: 30%
Beside the measured number, compound 4's estimate is 48 percentage points above it; the measured number lies below the stated range.
By their numbers in this assay, from the lowest: compound 4; then compound 3; then compounds 1 and 2 (each within the scatter of the next).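

In this assay, a nitrile on this phenyl does not by itself go with the higher response: a number 50 percentage points lower from compound 1 to compound 4 (beyond the scatter), although 4-cyanophenyl and 3-cyano-4-fluorophenyl both carry that group. A single added group at this position can shift the maximal response strongly, as the cyano group on plain phenyl gives a number 50 percentage points lower from compound 2 to compound 4 (beyond the scatter), so the earlier match between compound 1 and compound 2 does not mean that the position tolerates any substituent. The exchange of groups gives a number 25 percentage points lower from compound 3 to compound 4 (beyond the scatter), which places 4-cyanophenyl at the low end of the four compounds and leaves 3-cyano-4-fluorophenyl as the only substituted phenyl here within the scatter of plain phenyl.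

Nothing available bears on why these steps run as they do. The compounds shown also do not separate the contribution of the fluoro group in 3-cyano-4-fluorophenyl from that of the different nitrile placement, and they leave open whether an amine or a carboxylic acid in place of the nitrile of 4-cyanophenyl would keep the response as low.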